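One Side-Chain Swap, Measured Once, Expected Again

The compounds below may be only part of what the source reports. "The series", "measured", "known", "first", "only" and "open" are said of these compounds alone.

Compound 1 `COc1ccc(-c2nnc(SC/C(=N/O)c3ccccc3)n2-c2ccccc2)cc1` was tested in a functional assay on the whole organism (strain albino) for inhibition, with Rattus norvegicus as the target, read by paw edema, with a stated time of 4 h, at a dose of 0.28 mmol/kg by the oral route (a lower number here means less inhibition, a higher number more inhibition at the dose given (going by the name of the read-out)), where compound 1 gives 80%. Compound 3 `COc1ccc(-c2nnc(SCC(=O)c3ccccc3)n2-c2ccccc2)cc1` keeps the same core and differs only in the side chain attached through sulfur: a group of 8 heavy atoms (7 carbon, 1 oxygen; one six-membered aromatic ring of carbon only) in place of a group of 9 heavy atoms (7 carbon, 1 nitrogen, 1 oxygen; one six-membered aromatic ring of carbon only), on a saturated chain carbon bound to a sulfur. In this assay compound 3 gives 68%, so the change makes the step of a number 12 percentage points lower from compound 1 to compound 3 (beyond the scatter).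

Compound 2 `C=CCn1c(SC/C(=N/O)c2ccccc2)nnc1-c1cc(OC)c(OC)c(OC)c1` carries the same side chain as compound 1 but a different core; how the two cores differ is not broken down here. In this assay compound 2 gives 73%, which stands close to the numbers of compound 1 and compound 3, within the usual scatter of either.

Compound 4 `C=CCn1c(SCC(=O)c2ccccc2)nnc1-c1cc(OC)c(OC)c(OC)c1` has not yet been measured. It stands to compound 2 as compound 3 stands to compound 1: a group of 8 heavy atoms (7 carbon, 1 oxygen; one six-membered aromatic ring of carbon only) in place of a group of 9 heavy atoms (7 carbon, 1 nitrogen, 1 oxygen; one six-membered aromatic ring of carbon only), on a saturated chain carbon bound to a sulfur. The place of the change is worded the same way in both pairs, so this is the same change, made on a different core.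

Among the measured compounds shown here, the only guide to its effect is the measured step of a number 12 percentage points lower from compound 1 to compound 3 (beyond the scatter), seen once, on one core. Applied to the number of compound 2, the step from compound 2 to compound 4 is expected to be a number 12 percentage points lower from compound 2 to compound 4 (beyond the scatter). For compound 4 the estimated value in this assay is 61%. Given that the change has been seen only once and that the cores differ, compound 4 is expected to fall between 48% and 72%.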

Compound 4, a percentage reported as inhibition, in the whole organism at one dose (the size of the read-out at that dose, not a potency): 66%
Beside the measured number, compound 4's estimate is 5 percentage points below it, and the stated range covers the measured number.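

In this assay, putting benzoyl in place of the group of 9 heavy atoms, on a saturated chain carbon bound to a sulfur, gives a number 7 percentage points lower from compound 2 to compound 4 (within the scatter). Set beside the earlier step, this result gives no sign that the change behaves differently on the two cores: the same change on two cores in this assay, a number 12 percentage points lower (beyond the scatter) from compound 1 to compound 3 and a number 7 percentage points lower (within the scatter) from compound 2 to compound 4, 5 percentage points apart, within the scatter of two such steps What it does not show is that the change has a firm effect on the second core, since a step within the scatter alone cannot be told apart from no change, and two cores give no basis for a rule about other cores in this series.

The compounds shown leave open how a different group on the same saturated chain carbon, such as an amine, a carboxylic acid or a longer chain, would compare with benzoyl and with the group it replaces. They also leave open whether the same small gap would hold at other doses or at other times after dosing, since each compound is represented here by a single reading of paw edema, which is not a measure of potency.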